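A fluoro swap at the end of a small series

The source may hold more compounds than are shown below. What is called first, only, known or untested is meant among the compounds shown, and "the series" means these compounds.

Compound 1 `O=C1/C(=C/c2ccc(Cl)cc2)Cc2ccccc21`: in a functional assay on MOLT-4 cells (Homo sapiens) for inhibition (on this read-out higher numbers stand for weaker inhibition and lower numbers for stronger inhibition), compound 1 reaches only the limit > 500000 nM, which is not a number.
Compound 2 `Cc1cccc(/C=C2\Cc3ccccc3C2=O)c1`: compound 2 gives 80300 nM.
Compound 3 `O=C1/C(=C/c2ccccc2)CCc2ccccc21`: compound 3 gives 32400 nM.

Of the two numbers, compound 3 stands lowest; the nearest is compound 2, whose value lies higher by more than the usual scatter. Compound 4 `O=C1/C(=C/c2cccc(F)c2)CCc2ccccc21` has not yet been tested. It differs from compound 3 by fluoro in place of hydrogen on an aromatic carbon. Among the measured compounds shown here, no pair of measured compounds differs in a single place, so no measured step offers a guide. The change is small, and the step of a 1.1-fold lower number from compound 3 to compound 4 (0.03 log units; within the scatter) is expected to stay within the scatter, with no clear direction. Compound 4 is therefore estimated at 30000 nM, with a likely range from 10000 nM to 100000 nM.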

Compound 4, half-maximal inhibitory concentration: 11900 nM
The estimate for compound 4 lay 2.5-fold (0.40 log units) above the measured number, within the range that was stated.
By their numbers in this assay, from the lowest: compound 4; then compound 3; then compound 2. At a limit, above all of these: compound 1.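

Fluoro in place of hydrogen, on an aromatic carbon meta to a large group, gives a 2.7-fold lower number from compound 3 to compound 4 (0.43 log units; beyond the scatter) in this assay. Among the compounds shown here, this is the first change in one place that can be read in this small series, and it shows that a single added heavy atom at this position can move the number beyond the usual scatter. Nothing among the data given explains the step.

Still open, from the compounds shown here alone, is how an amine or a carboxylic acid would fare at this same position. Going by these compounds, it is also open whether fluoro would give a similar step on another carbon of that ring.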